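Amine substituent series: from sec-butyl to cyclohexyl

The source may hold more compounds than are shown below. What is called first, only, known or untested is meant among the compounds shown, and "the series" means these compounds.

Measured compounds, with their read-out in a functional assay on Caco-2 cells (Homo sapiens), read by fluorescence, tested at 10 uM; a higher number here means a weaker effect of the compound at the concentration tested, a lower number a stronger effect:
compound 1 `CC(C)CNC(=C\C(=O)/C=C/c1ccc(O)cc1)/C=C/c1ccc(O)cc1`: 82%
compound 2 `CCC(C)NC(=C\C(=O)/C=C/c1ccc(O)cc1)/C=C/c1ccc(O)cc1`: 102%
compound 3 `CCC(C)NC(=C\C(=O)/C=C/c1ccc(OC(C)=O)c(OC)c1)/C=C/c1ccc(OC(C)=O)c(OC)c1`: 86%

Compound 2 gives the highest of the three numbers in this assay. Compound 3 stands nearest with 86%, a gap beyond the scatter; compound 1 stands furthest with 82%, also beyond the scatter. Going by the values given here, the only single-point step among the measured compounds is a number 20 percentage points higher from compound 1 to compound 2 (beyond the scatter), an exchange of one alkyl group on the amine nitrogen for another.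

Compound 4 `O=C(/C=C(/C=C/c1ccc(O)cc1)NC1CCCCC1)/C=C/c1ccc(O)cc1` is not yet measured. It differs from compound 2 in one place: cyclohexyl in place of sec-butyl on an amine nitrogen. Among the compounds with values here, the step from compound 1 to compound 2 is the only measured change at the same place, and it was modest; it bears on compound 4 only in that a new alkyl group on the amine nitrogen can shift the read-out by a modest amount in either direction. Within the data shown here, no measured step covers a cyclohexyl group, so the direction is open. For compound 4 a step of a number 10 percentage points lower from compound 2 to compound 4 (within the scatter) is expected, small and within or near the scatter. Compound 4 is therefore estimated at 92%, with a range from 74% to 110%.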

Compound 4, a percentage reported as activity, at one concentration (the size of the read-out at that concentration, not a potency): 82%
Compound 4: middle estimate off by 10 percentage points, on the high side; the measured number falls inside the stated range.
By their numbers in this assay, from the lowest: compounds 1, 4 and 3 (each within the scatter of the next); then compound 2.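

In this assay the exchange of sec-butyl for cyclohexyl on the amine nitrogen gives a number 20 percentage points lower from compound 2 to compound 4 (beyond the scatter) and so shows that the read-out at this position also moves when a ring enters. Against the isobutyl group the same ring gives no change at the digits printed from compound 1 to compound 4 (within the scatter) and thus no separation, so a ring is not needed for the lower number, and among these three alkyl groups sec-butyl alone stands apart. Nothing available explains why these groups differ in this way.

From the compounds shown here alone, it remains open whether a straight n-butyl chain, a cyclopentyl ring or a benzyl group on the same nitrogen would read with sec-butyl or with isobutyl and cyclohexyl. Also open, going by these compounds, is whether the cyclohexyl result carries over to the acetoxy and methoxy aryl groups of compound 3.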